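Notes on the step from compound 2 to compound 3

The compounds below may be only part of what the source reports. "The series", "measured", "known", "first", "only" and "open" are said of these compounds alone.

In a functional assay on PC-3 cells (Homo sapiens) for antiproliferative activity, read by sulforhodamine B assay, with a stated time of 72 h (a lower number here means a stronger inhibitor, a higher number a weaker inhibitor), compound 1 `COc1ncc(-c2ccc3ncc(NC(=O)C4CCCCC4)c(OC)c3c2)cc1NS(=O)(=O)c1ccc(F)cc1F` gives 6630 nM and compound 2 `CCNc1cnc2ccc(-c3cnc(OC)c(NS(=O)(=O)c4ccc(F)cc4F)c3)cc2c1OC` gives 4820 nM. Going by the values given here, compound 2 therefore stands level with compound 1, the only other measured compound, since the gap between them lies within the scatter. Compound 3 `COc1ncc(-c2ccc3ncc(NC(=O)CN4CCN(C)CC4)c(OC)c3c2)cc1NS(=O)(=O)c1ccc(F)cc1F` carries ((4-methylpiperazin-1-yl)methyl)carbonyl in place of ethyl on a nitrogen on an aromatic ring. Among the compounds with values here, one measured step bears on this change. It concerns the same nitrogen, where ethyl takes the place of cyclohexylcarbonyl, and it reads a 1.4-fold lower number from compound 1 to compound 2 (0.14 log units; within the scatter). That step shows no separation in this assay between a carbonyl-bearing group and ethyl at this place. Within the data shown here, it is a single pair, however, and no measured compound carries the entering group, so the expectation is loose. No step beyond the scatter is expected, and the estimated step is a 1.1-fold lower number from compound 2 to compound 3 (0.03 log units; within the scatter). The expected value for compound 3 is 4500 nM, with an estimated range of 1500 nM to 12000 nM.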

Compound 3, half-maximal inhibitory concentration: 1730 nM
Compound 3: the middle estimate sits 2.6-fold (0.42 log units) above what was measured, and the stated range covers the measured number.
By their numbers in this assay, from the lowest: compound 3; then compounds 2 and 1 (each within the scatter of the next).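

In this assay the nitrogen on an aromatic ring now separates its substituents, since ((4-methylpiperazin-1-yl)methyl)carbonyl in place of ethyl gives a 2.8-fold lower number from compound 2 to compound 3 (0.45 log units; beyond the scatter) and thus a step beyond the scatter, which the earlier pair at this nitrogen did not show. With the carbonyl held constant, (4-methylpiperazin-1-yl)methyl in place of cyclohexyl on a carbonyl carbon gives a 3.8-fold lower number from compound 1 to compound 3 (0.58 log units; beyond the scatter) as a step of modest size, so among these compounds a carbonyl alone does not mark the lower number: compound 1 carries one and stands level with compound 2, and only compound 3 carries the 4-methylpiperazin-1-yl group. Nothing available here explains either step.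

Going by these compounds, it remains open whether the step follows the ring itself, its methyl group or its second nitrogen, which a morpholine or an unsubstituted piperazine at the same place would test. Also open, on these data alone, is whether the carbonyl is required, which a 2-(4-methylpiperazin-1-yl)ethyl group on this nitrogen would test, and how a longer chain linking the carbonyl to the ring would read.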